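The source may hold more compounds than are shown below. What is called first, only, known or untested is meant among the compounds shown, and "the series" means these compounds.

Compound 2 `CC(=O)Oc1ccc(-c2ccc(F)cc2F)cc1C(=O)Nc1ccccc1` gives 8.9% in a functional assay on the whole organism (strain Kunming) for inhibition, with Mus musculus as the target, in the writhing test, at a dose of 40 mg/kg by the oral route; on this read-out higher numbers stand for more inhibition at the one dose given (going by the name of the read-out) and lower numbers for less inhibition. On the numbers shown it stands lowest of the two measured compounds, with compound 1 `CC(=O)Oc1ccc(-c2ccc(F)cc2F)cc1C(=O)NCc1ccccc1` nearest at 16.6%, and the two values lie within the scatter of each other. Compound 3 `CC(=O)Oc1ccc(-c2ccc(F)cc2F)cc1C(=O)Nc1cccc(C)c1` has not yet been measured. It differs from compound 2 in one place: methyl in place of hydrogen on an aromatic carbon. Among the compounds with values here, only one measured step exists, a number 7.7 percentage points lower from compound 1 to compound 2 (within the scatter), and it concerns the group on the amide nitrogen rather than a methyl on an aromatic carbon, so it bears on the new change only loosely; it was itself within the scatter. Within the data shown here, nothing among the measured compounds speaks for a shift beyond the scatter, and compound 3 is therefore expected to give about 12%, between 0% and 28%, in this assay. The expected step of a number 3.1 percentage points higher from compound 2 to compound 3 (within the scatter) is thus estimated to be small.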

Compound 3, a percentage reported as inhibition, in the whole organism at one dose (the size of the read-out at that dose, not a potency): 19%
Compound 3: middle estimate off by 7 percentage points, on the low side, within the range that was stated.
By their numbers in this assay, from the lowest: compounds 2, 1 and 3 (each within the scatter of the next, the first and the last beyond it).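

In this assay, within the data shown here, going from phenyl to 3-methylphenyl on the amide nitrogen gives the first step that passes the usual scatter: a number 10.1 percentage points higher from compound 2 to compound 3 (beyond the scatter). This single added methyl therefore has a modest but readable effect at this position, whereas the change of the nitrogen group from benzyl to phenyl did not pass the scatter. The comparison with the benzyl compound gives a number 2.4 percentage points higher from compound 1 to compound 3 (within the scatter), so 3-methylphenyl and benzyl on that nitrogen cannot be told apart on this read-out, and no measurement here offers an explanation for the methyl step.

On these data alone, it remains open whether an ethyl, a methoxy or a chlorine in the same place would give a similar number. The same holds for a methyl on the ring of the benzyl group.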